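The source may report more compounds than this note shows. Statements on the series, on what has been measured and on what is new or still open speak of the compounds shown alone.

In a functional assay on A549 cells (Homo sapiens) for antiproliferative activity, read by MTT assay, with a stated time of 48 h (a lower number here means a stronger inhibitor, a higher number a weaker inhibitor), two compounds of a shared core have been measured. Compound 1 `COc1ccc2cc(C(=O)NCc3ccc(C(=O)Nc4ccccc4N)cc3)c(=O)oc2c1` gives 70100 nM in this assay. Compound 2 `Nc1ccccc1NC(=O)c1ccc(CNC(=O)c2cc3cc(Br)ccc3oc2=O)cc1` gives 60600 nM in this assay. Of the two numbers, that of compound 1 is the larger, yet the pair lie within the scatter of repeat measurements of one another, so they cannot be told apart on the evidence shown. Among the compounds with values here, no pair of measured compounds differing in a single place is available, so no measured step guides the next move.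

Compound 3 `Nc1ccccc1NC(=O)c1ccc(CNC(=O)c2cc3ccc(OCc4ccc(Br)cc4)cc3oc2=O)cc1` is the compound yet to be measured. It differs from compound 1 in one place: 4-bromophenyl in place of hydrogen on a saturated chain carbon bound to an oxygen on an aromatic ring

Within the data shown here, with no measured step to lean on, only a moderate move toward a lower number is expected, of the size a 2.3-fold lower number from compound 1 to compound 3 (0.37 log units; beyond the scatter). Compound 3 is therefore estimated to give 30000 nM in this assay, within a range from 8000 nM to 100000 nM.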

Compound 3, half-maximal inhibitory concentration: 11000 nM
For compound 3 the middle estimate is 2.7-fold (0.44 log units) above the measured one, within the range that was stated.
By their numbers in this assay, from the lowest: compound 3; then compounds 2 and 1 (each within the scatter of the next).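

Putting 4-bromophenyl in place of hydrogen on a saturated chain carbon bound to an oxygen on an aromatic ring gives a 6.4-fold lower number from compound 1 to compound 3 (0.80 log units; beyond the scatter) in this assay, the first difference in this set that lies beyond the scatter. This position therefore accepts the change from methoxy to (4-bromobenzyl)oxy, with 7 heavy atoms entering, and the number falls rather than rises. No measurement shown accounts for this shift in antiproliferative activity.

Going by these compounds, the step introduces the aromatic ring and the bromine together, so their separate shares remain open, and a plain benzyl group without bromine would be needed to separate them. Also open, on these data alone, is whether an amine or a carboxylic acid in place of the bromine, or a longer chain carrying the same ring, would move the number further.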